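Isopropoxy in place of hydrogen on the pyrimidine of compound 1

A few compounds are considered here, and "the series" means these few. Any claim that something is new, unique, unknown or untested is made for them only; others in the source may bear on it.

Measured so far in an assay on brain for binding affinity to Adrenergic receptor alpha-1 (Rattus norvegicus); a higher number here means a weaker inhibitor, a lower number a stronger inhibitor:
Compound 1, `COc1cc2nc(N3CCN(c4ccncn4)CC3)nc(N)c2cc1OC`, gives 0.27 nM.
Compound 2, `COc1cc2nc(N3CCN(c4nccc(N(C)C)n4)CC3)nc(N)c2cc1OC`, gives 0.27 nM.
Compound 3, `CCCOc1cc(N2CCN(c3nc(N)c4cc(OC)c(OC)cc4n3)CC2)ncn1`, gives 0.36 nM.

Compound 1 stands level with compound 2 at the digits shown, and together they hold the lowest numbers of the three; the step of no change at the digits printed from compound 1 to compound 2 (within the scatter) lies within the scatter, and so does a 1.3-fold higher number from compound 1 to compound 3 (0.12 log units; within the scatter). The unmeasured compound 4, `COc1cc2nc(N3CCN(c4cc(OC(C)C)ncn4)CC3)nc(N)c2cc1OC`, differs from compound 1 by isopropoxy in place of hydrogen on an aromatic carbon.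

The step that bears most directly on this change is a 1.3-fold higher number from compound 1 to compound 3 (0.12 log units; within the scatter), where propoxy entered in place of hydrogen at the same kind of site and the number stayed within the scatter. The step of a 1.3-fold higher number from compound 2 to compound 3 (0.12 log units; within the scatter), which also ends at a propoxy-bearing pyrimidine, was equally small. Isopropoxy is a close relative of propoxy, so the expectation for compound 4 in this assay is a step of about a 1.3-fold higher number from compound 1 to compound 4 (0.11 log units; within the scatter), that is, no change beyond the scatter. Compound 4 is therefore estimated at 0.35 nM, within a range from 0.15 nM to 0.8 nM.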

Compound 4, inhibition constant: 0.18 nM
For compound 4 the middle estimate is 1.9-fold (0.29 log units) above the measured one, and the stated range covers the measured number.
By their numbers in this assay, from the lowest: compounds 4, 1, 2 and 3 (each within the scatter of the next).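

In this assay isopropoxy on this aromatic carbon gives a 1.5-fold lower number from compound 1 to compound 4 (0.18 log units; within the scatter) and so, like the propoxy of compound 3, is accepted here without a change beyond the scatter. Swapping propyl for isopropyl on the oxygen gives a 2.0-fold lower number from compound 3 to compound 4 (0.30 log units; within the scatter) and replacing the whole pyrimidine substituent of compound 2 gives a 1.5-fold lower number from compound 2 to compound 4 (0.18 log units; within the scatter), so neither the form of this chain nor the choice between these substituents separates the compounds shown. No measurement is available to explain why these numbers stay so close. 

Still open, from the compounds shown here alone, is whether a group of another kind on this carbon, such as a carboxylic acid or a longer chain like hexyloxy, would move the number beyond the scatter. Going by these compounds, how far this tolerance extends therefore remains unknown.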